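The compounds below may be only part of what the source reports. "The series", "measured", "known", "first", "only" and "open" are said of these compounds alone.

Measured compounds:
- compound 1, `O=C(Nc1cccc(-c2nc(-c3ccc(NC(=O)c4cccnc4)cc3Cl)no2)c1)c1ccccc1`, in a functional assay on MDA-MB-231 cells (Homo sapiens) for antiproliferative activity, read by MTT assay, with a stated time of 72 h (a lower number here means a stronger inhibitor, a higher number a weaker inhibitor), compound 1 gives 12800 nM
- compound 2, `O=C(Nc1ccc(-c2noc(-c3cccc(NS(=O)(=O)c4cccc(Cl)c4)c3)n2)c(Cl)c1)c1cccnc1`, in this assay compound 2 gives > 10000 nM, a limit of the assay, not a number
- compound 3, `Cc1ccc(S(=O)(=O)Nc2cccc(-c3nc(-c4ccc(NC(=O)c5cccnc5)cc4Cl)no3)c2)cc1`, in this assay compound 3 gives > 10000 nM, again only a limit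

Compound 3 thus stands at the limit, the weaker end of the three. Compound 4, `CC(=O)Nc1ccc(S(=O)(=O)Nc2cccc(-c3nc(-c4ccc(NC(=O)c5cccnc5)cc4Cl)no3)c2)cc1`, differs from compound 3 by acetamido in place of methyl on an aromatic carbon. The steps a step that the limit leaves unreadable from compound 1 to compound 3 and a step that the two limits leave unreadable from compound 2 to compound 3 bear on this series but are unreadable because of the limit of > 10000 nM in this assay, at which 2 of the 3 values shown sit; nothing measured shows how the group on the sulfonyl ring shifts the value. Compound 4 is expected to stay near the limit, with an estimated step that the limit leaves unreadable from compound 3 to compound 4. The estimate for compound 4 is 15000 nM, expected between 5000 nM and 50000 nM.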

Compound 4, half-maximal inhibitory concentration: 2500 nM
The estimate for compound 4 lay 6.0-fold (0.78 log units) above the measured number; measured number below the stated range.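

In this assay, within the data shown here, the group on the sulfonyl-bound ring does move the value: acetamido in place of methyl gives an at least 4.0-fold lower number from compound 3 to compound 4 (0.60 log units; beyond the scatter), the first readable step at this position. Swapping 3-chlorophenyl for 4-acetamidophenyl on the sulfonyl sulfur likewise gives an at least 4.0-fold lower number from compound 2 to compound 4 (0.60 log units; beyond the scatter). The remaining steps among these compounds cannot be read: the limit of > 10000 nM in this assay, at which 2 of the 4 values shown sit.

As far as these compounds go, it remains open whether the whole acetamido group is needed for this step, or only its amide hydrogen or its carbonyl. From the compounds shown here alone, it is equally open whether an amine or a carboxylic acid at the same place would lower the number further.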